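The source may hold more compounds than are shown below. What is called first, only, known or untested is meant among the compounds shown, and "the series" means these compounds.

Values in a functional assay on HL-60 cells (Homo sapiens) for cytotoxicity, read by luminescence and CellTiter-Glo, with a stated time of 3 days (a higher number here means a weaker inhibitor, a lower number a stronger inhibitor), so far:
Compound 1 `COc1ccc(O)c(C(=O)Nc2ccc(C#N)cc2)c1` gives > 10000 nM (a limit of the assay, not a number)
Compound 2 `N#Cc1ccc(NC(=O)c2cc(-c3cccnc3)ccc2O)cc1` gives 7960 nM
Compound 3 `O=C(Nc1ccc(C(F)(F)F)c(Cl)c1)c1cc(Cl)ccc1O` gives 460 nM

Compound 1 sits at the limit of > 10000 nM in this assay, at which 1 of the 3 values shown sits, and so has a limit only. Of the two actual numbers, compound 2 has the higher, 7960 nM, and compound 3 gives 460 nM. The gap between these two lies beyond the scatter.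

The next step leads to compound 4 `Cc1ccc(O)c(C(=O)Nc2ccc(C#N)cc2)c1`, with methyl in place of pyridin-3-yl on an aromatic carbon, para to a hydroxy group (methyl in place of pyridin-3-yl on an aromatic carbon). Going by the values given here, the one measured step that bears on this change puts pyridin-3-yl in place of methoxy, and it is an at least 1.2-fold lower number from compound 1 to compound 2 (0.09 log units; that floor lies within the scatter). That step rests on the limit of compound 1, so it gives only a floor. Among the compounds with values here, no measured step connects compound 3 to this change.

No step beyond the scatter is therefore expected in this assay, and the series should stay at the weak end of the range. The expected size of the change is a 1.1-fold higher number from compound 2 to compound 4 (0.05 log units; within the scatter) as an estimate. For compound 4 the estimated value is 9000 nM, with an expected range from 3500 nM to 20000 nM, and a report of a limit alone would be no surprise.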

Compound 4, half-maximal inhibitory concentration: 3920 nM
Compound 4: middle estimate off by 2.3-fold (0.36 log units), on the high side; measured number inside the range.
By their numbers in this assay, from the lowest: compound 3; then compound 4; then compound 2. At a limit, above all of these: compound 1.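

In this assay, the position para to a hydroxy group now shows a change that clears the scatter: a 2.0-fold lower number from compound 2 to compound 4 (0.31 log units; beyond the scatter). Here a single methyl carbon replaces the six-membered aromatic ring of pyridin-3-yl and gives the lower number, so a ring at this position is not needed for the activity seen in this small set. Methyl in place of methoxy gives an at least 2.5-fold lower number from compound 1 to compound 4 (0.40 log units; beyond the scatter), whereas pyridin-3-yl in place of methoxy gave only an at least 1.2-fold lower number from compound 1 to compound 2 (0.09 log units; that floor lies within the scatter), and the true size of both steps stays unknown because compound 1 is held at a limit, not a number: the limit of > 10000 nM in this assay, at which 1 of the 4 values shown sits.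

From the compounds shown here alone, whether an amine, a carboxylic acid or a longer chain at this position would move the number further in either direction remains open, since only methoxy, methyl and pyridin-3-yl can be compared here on the nitrile-bearing core. Compound 3 carries chloro para to a hydroxy group but also differs on the other aromatic ring, so the contribution of chloro at this position cannot be separated from that of the other changes.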